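The source may report more compounds than this note shows. Statements on the series, on what has been measured and on what is new or still open speak of the compounds shown alone.

In a physicochemical assay for solubility (on this read-out lower numbers stand for lower solubility and higher numbers for higher solubility), compound 2 `CNC(=O)c1sc(N2CC3CC2(CNC(=O)c2c[nH]c4ncc(C(F)(F)F)cc24)C3)nc1C(F)(F)F` reads < 1600 nM, which is a limit of the assay and not a number. Compound 1 `COc1cc2c(Nc3cnc(NC(=O)c4cccn4C)nc3)ncnc2cc1OCCCNC1CCCC1` gives 1000000 nM and compound 3 `CN(Cc1ccc2nccn2c1)c1nnc(-c2ncc(C(F)(F)F)cc2Cl)o1` gives 301000 nM. As far as these compounds go, compound 2 therefore sits at the low end of the values in hand, though its exact position is unknown.

The next compound is compound 4 `CNC(=O)c1sc(N2CC3CC2(CNC(=O)c2c[nH]c4ncc(C)cc24)C3)nc1C(F)(F)F`, not yet measured, which carries methyl in place of trifluoromethyl on an aromatic carbon of a six-membered aromatic ring with 1 nitrogen: methyl in place of trifluoromethyl on an aromatic carbon. Among the measured compounds shown here, no measured pair shows this change or any other single change, so the expectation rests on the structural change alone. A modest upward step in this assay is expected, and a reading again reported only as a limit remains quite possible. The estimated change is an at least 1.8-fold higher number from compound 2 to compound 4 (0.27 log units; that floor lies within the scatter), reckoned against a limit and not a number. The expected value for compound 4 is 3000 nM, with an estimated range from 1000 nM to 20000 nM.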

Compound 4, solubility: < 1600 nM
Compound 4 gave a limit, no number; the forecaster's own chance of this, stated with the estimate: 40%; middle value at least 1.8-fold (0.27 log units) from the limit.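

In this assay, compound 2 and compound 4 both read as limits and not numbers, so no step can be read between them: the limit of < 1600 nM in this assay, at which 2 of the 4 values shown sit. The compounds shown leave open whether methyl in place of trifluoromethyl on an aromatic carbon shifts this read-out at all, and in which direction.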